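From fluoro to dimethylamino: an unmeasured kind of change

The source may report more compounds than this note shows. Statements on the series, on what has been measured and on what is new or still open speak of the compounds shown alone.

In a functional assay on aorta (strain Wistar) for inhibition, with Thoracic aorta (Rattus norvegicus) as the target (a higher number here means a weaker inhibitor, a lower number a stronger inhibitor), compound 2 `COc1nc(-c2cc3ccccc3o2)cc(-c2ccc(F)cc2)c1C#N` gives 321000 nM. Compound 1 `COc1nc(-c2cc3ccccc3o2)cc(-c2ccc(Br)cc2)c1C#N` gives 298000 nM, and the step of a 1.1-fold higher number from compound 1 to compound 2 (0.03 log units; within the scatter) lies within the scatter, so the two compounds stand together. Compound 3 `COc1nc(-c2cc3ccccc3o2)cc(-c2ccc(N(C)C)cc2)c1C#N` differs from compound 2 by dimethylamino in place of fluoro on an aromatic carbon. Going by the values given here, the only measured step is a halogen swap and bears little on this change; the data hold nothing of this kind, so no step beyond the scatter is expected in this assay in either direction. Compound 3 is therefore estimated at 300000 nM, with a range from 100000 nM to 900000 nM. This expected estimate means a step of a 1.1-fold lower number from compound 2 to compound 3 (0.03 log units; within the scatter).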

Compound 3, half-maximal inhibitory concentration: 278000 nM
Beside the measured number, compound 3's estimate is 1.1-fold (0.03 log units) above it, within the range that was stated.
By their numbers in this assay, from the lowest: compounds 3, 1 and 2 (each within the scatter of the next).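

In this assay, dimethylamino on the aromatic carbon para to a large group gives a 1.2-fold lower number from compound 2 to compound 3 (0.06 log units; within the scatter) and, set against bromo, a 1.1-fold lower number from compound 1 to compound 3 (0.03 log units; within the scatter). This position therefore accepts a nitrogen-bearing group with more heavy atoms, not only a halogen, without a step beyond the scatter. No supporting evidence bears on why these three compounds stand together. Still open, going by these compounds, is whether a carboxylic acid, a primary amine or a longer chain at this position would move the number beyond the scatter. Also open, on these data alone, is whether any change elsewhere on the shared core would do so.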